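Swapping a Chlorophenyl for a Methoxystyryl Arm

The source may report more compounds than this note shows. Statements on the series, on what has been measured and on what is new or still open speak of the compounds shown alone.

Compound 1 `CCCCCCCCS(=O)(=O)Nc1cc(-c2cccc(Cl)c2)ccc1C(=O)O` is the stronger of the two measured compounds in an assay on mitochondria (strain BALB/c) for inhibition of glycerol-3-phosphate acyltransferase 1, mitochondrial (Mus musculus), read by scintillation counting, with a stated time of 10 min (a higher number here means a weaker inhibitor, a lower number a stronger inhibitor), where compound 1 gives 13800 nM. Compound 2 `CCCCCCCCS(=O)(=O)Nc1ccc(C(=O)c2ccc(OC)cc2)cc1C(=O)O` shares the core of compound 1 but carries a different arm, and in this assay compound 2 gives 44300 nM, a gap beyond the scatter. Compound 3 `CCCCCCCCS(=O)(=O)Nc1cc(/C=C/c2ccc(OC)cc2)ccc1C(=O)O` differs from compound 1 in one place: 2-(4-methoxyphenyl)ethenyl in place of 3-chlorophenyl on an aromatic carbon. Within the data shown here, no measured pair shows such a change, so the direction is open; a modest weakening, near the edge of the scatter, is expected for the step of a 1.6-fold higher number from compound 1 to compound 3 (0.20 log units; within the scatter). Compound 3 is expected to give about 22000 nM, estimated between 7000 nM and 70000 nM.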

Compound 3, half-maximal inhibitory concentration: 38700 nM
The estimate for compound 3 lay 1.8-fold (0.25 log units) below the measured number; the measured number falls inside the stated range.
By their numbers in this assay, from the lowest: compound 1; then compounds 3 and 2 (each within the scatter of the next).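

Moving from 3-chlorophenyl to 2-(4-methoxyphenyl)ethenyl on this aromatic carbon, para to the carboxy group, costs strength in this assay (a 2.8-fold higher number from compound 1 to compound 3 (0.45 log units; beyond the scatter)). This position therefore responds to the choice of arm, and here the chlorophenyl arm is the better of the two. No measurement is available that explains this loss.

The ring's substituent, its place on the ring and the double bond all change in this one step, and the compounds shown do not separate them. Going by these compounds, how a 3-methoxyphenyl group, or an amine or carboxylic acid on that arm, would fare remains open.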